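Swapping the Amide Cap on a Shared Alkyne Core

The source may report more compounds than this note shows. Statements on the series, on what has been measured and on what is new or still open speak of the compounds shown alone.

Three measured compounds share one core with an alkyne to a phenyl ring and differ only in what sits on the ring nitrogen. Compound 1 `CN1CCc2nc(C#Cc3ccccc3)sc2C1` carries a methyl there. In an assay on HEK293 cells for negative allosteric modulation of metabotropic glutamate receptor 5 (Homo sapiens), read by FLIPR, with a stated time of 1 h (a lower number here means a stronger inhibitor, a higher number a weaker inhibitor), compound 1 gives only a limit, > 10000 nM. Compound 2 `CCCCN1CCc2nc(C#Cc3ccccc3)sc2C1` carries a butyl instead. In this assay compound 2 likewise gives only a limit, > 10000 nM. Compound 3 `CC1CC(C(=O)N2CCc3nc(C#Cc4ccccc4)sc3C2)C1` turns the nitrogen into an amide with a (3-methylcyclobutyl)carbonyl. In this assay compound 3 again gives only a limit, > 10000 nM. Because all three sit at the limit of > 10000 nM in this assay, at which 3 of the 3 values shown sit, the steps a step that the two limits leave unreadable from compound 1 to compound 2, a step that the two limits leave unreadable from compound 1 to compound 3 and a step that the two limits leave unreadable from compound 2 to compound 3 have no readable size, and compound 3 stands at the limit rather than at a number.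

Compound 4 `N#Cc1cccc(C(=O)N2CCc3nc(C#Cc4ccccc4)sc3C2)c1` keeps the amide and changes its cap: 3-cyanophenyl in place of 3-methylcyclobutyl on a carbonyl carbon. The two steps that touch this amide are the unreadable ones from compound 1 and compound 2 to compound 3, so nothing measured sets a size or direction for the new step; it could stay at the limit or move to a readable number.

For compound 4 the expected value in this assay is therefore 5000 nM, with a wide expected range from 500 nM to 20000 nM. That estimate implies an expected step of an at least 2.0-fold lower number from compound 3 to compound 4 (0.30 log units; that floor lies within the scatter), stated with low confidence.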

Compound 4, half-maximal inhibitory concentration: > 10000 nM
Compound 4: only a limit was reported (the forecaster's own chance of this, stated with the estimate: 50%); middle value at least 2.0-fold (0.30 log units) away from the limit.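

In this assay compound 4 gives only a limit, > 10000 nM. Compound 3 also sits at a limit, so the change from compound 3 to compound 4 has no readable size: the limit of > 10000 nM in this assay, at which 4 of the 4 values shown sit.

The compounds shown leave open how the groups on the ring nitrogen rank against one another, and whether any of them gives a readable number.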